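A Third Aryl Variant on a Tolerated Scaffold

A few compounds are considered here, and "the series" means these few. Any claim that something is new, unique, unknown or untested is made for them only; others in the source may bear on it.

Compound 1 `Cc1nc(-c2cccnc2)sc1-c1nnc(-c2cccnc2)o1` serves as the starting point. In an ADME assay on THP-1 cells (Homo sapiens) for cytotoxicity, read by MTT assay (a higher number here means that more compound is tolerated, a lower number that less compound is tolerated), compound 1 gives > 100 ug/mL, a limit of the assay rather than a number. Two analogues alter the same aromatic carbon. Compound 2 `Cc1ccc(-c2nnc(-c3sc(-c4cccnc4)nc3C)o2)cc1` gives > 100 ug/mL in this assay, likewise a limit. Compound 3 `COc1ccccc1-c1nnc(-c2sc(-c3cccnc3)nc2C)o1` gives > 100 ug/mL in this assay, also a limit. As a result the steps a step that the two limits leave unreadable from compound 1 to compound 2 and a step that the two limits leave unreadable from compound 1 to compound 3 cannot be sized, and the same holds for a step that the two limits leave unreadable from compound 2 to compound 3; what the data do show is the limit of > 100 ug/mL in this assay, at which 3 of the 3 values shown sit.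

Compound 4 `Cc1cccc(-c2nnc(-c3sc(-c4cccnc4)nc3C)o2)c1` has not yet been measured. Its change from compound 1 is 3-methylphenyl in place of pyridin-3-yl on an aromatic carbon. The two measured exchanges at this position, 4-methylphenyl and 2-methoxyphenyl in place of pyridin-3-yl, both left the read-out at the limit, so no step beyond the scatter in either direction is expected here, and the expected step that the limit leaves unreadable from compound 1 to compound 4 reflects that. Compound 4 is estimated to give 150 ug/mL, with a range from 80 ug/mL to 400 ug/mL, most probably reported again as a limit.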

Compound 4, half-maximal cytotoxic concentration: > 100 ug/mL
Compound 4 gave a limit, no number (the forecaster's own chance of this, stated with the estimate: 85%); the middle value lies beyond the limit too.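

The steps to compound 4 from compound 1, compound 2 and compound 3 cannot be read, since each joins two limits in this assay: the limit of > 100 ug/mL in this assay, at which 4 of the 4 values shown sit.

The compounds shown leave open what concentration of any of them is cytotoxic, and whether any exchange at this position changes the read-out at all.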